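A few compounds are considered here, and "the series" means these few. Any claim that something is new, unique, unknown or untested is made for them only; others in the source may bear on it.

Working notes on the series.

Compound 1 `CCn1c(C(=O)NCCC(=O)OC)ccc1C(CC)(CC)c1ccc(OCS(=O)(=O)c2ccccc2)c(C)c1` is the reference point. In a functional assay on BXPC-3 cells (Homo sapiens) for antiproliferative activity, read by MTT assay, with a stated time of 24 h (on this read-out higher numbers stand for weaker inhibition and lower numbers for stronger inhibition), compound 1 gives > 50000 nM, which is a limit of the assay and not a number. Compound 2 `CCn1c(C(=O)NCCNC(=O)OC(C)(C)C)ccc1C(CC)(CC)c1ccc(OCS(=O)(=O)c2ccccc2)c(C)c1` carries (tert-butoxycarbonyl)amino in place of methoxycarbonyl on a saturated chain carbon, two bonds along the chain from an amide-type nitrogen. In this assay compound 2 gives > 50000 nM, again a limit. The resulting step that the two limits leave unreadable from compound 1 to compound 2 is therefore not readable, because the limit of > 50000 nM in this assay, at which 2 of the 2 values shown sit, covers both values shown. Among the measured compounds shown here, compound 1 thus stands at a limit only, and the one neighbouring value is a limit as well, so no numbered position exists for it.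

Compound 3 `CCn1c(C(=O)N[C@H](C(=O)O)C(C)C)ccc1C(CC)(CC)c1ccc(OCS(=O)(=O)c2ccccc2)c(C)c1` differs from compound 1 by 1-carboxy-2-methylpropyl in place of 2-(methoxycarbonyl)ethyl on an amide-type nitrogen. For the measured compounds named here, the only measured step that touches the shared core and its amide-type nitrogen, from compound 1 to compound 2, is unreadable, so no size or direction can be drawn from it. With nothing beyond the limit available, compound 3 is expected to remain at that limit, meaning a number no higher from compound 1 to compound 3 (the limit leaves the size open) is estimated to be nothing readable. The estimate for compound 3 in this assay is 50000 nM, within a range of 20000 nM to 150000 nM.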

Compound 3, half-maximal inhibitory concentration: 16200 nM
Beside the measured number, compound 3's estimate is 3.1-fold (0.49 log units) above it; measured number below the stated range.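

In this assay, among the compounds shown here, 1-carboxy-2-methylpropyl on the amide-type nitrogen gives the first readable step at this position, an at least 3.0-fold lower number from compound 1 to compound 3 (0.48 log units; beyond the scatter), where the exchange of the earlier chains left nothing to read. The same group in place of 2-((tert-butoxycarbonyl)amino)ethyl gives an at least 3.0-fold lower number from compound 2 to compound 3 (0.48 log units; beyond the scatter), so the lower number appears against both earlier chains and this position is shown to respond to the group it carries. Both steps give only a minimum size, not a full one, and the true distance from either earlier compound stays unknown: the limit of > 50000 nM in this assay, at which 2 of the 3 values shown sit.

The change brings in a free carboxylic acid, a branched chain and a defined stereocentre all at once, and the compounds shown leave open which of these goes with the lower number. A 2-carboxyethyl group on the same nitrogen would keep the unbranched chain with a carboxylic acid, the methyl ester of 1-carboxy-2-methylpropyl would keep the branch without one, and the opposite stereocentre would test the configuration.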